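Taking the amino group off compound 3

The compounds below may be only part of what the source reports. "The series", "measured", "known", "first", "only" and "open" are said of these compounds alone.

Measured in an assay for inhibition of MAP kinase-interacting serine/threonine-protein kinase 2 (Homo sapiens), read by luminescence and ADP-Glo, with a stated time of 2 h; a higher number here means a weaker inhibitor, a lower number a stronger inhibitor:
compound 1 `Nc1n[nH]c2cc(-c3ccc(=O)n(Cc4ccccc4)c3)ccc12`: 32 nM
compound 2 `O=c1ccc(-c2ccc3cn[nH]c3c2)cn1Cc1ccccc1`: 75 nM
compound 3 `CC(=O)Nc1cccc(Cn2cc(-c3ccc4c(N)n[nH]c4c3)ccc2=O)c1`: 8 nM

Compound 3 stands lowest of the three numbers. Its nearest neighbour is compound 1, separated by the step of a 4.0-fold lower number from compound 1 to compound 3 (0.60 log units; beyond the scatter); compound 2 sits furthest from it, and compound 3 is the strongest inhibitor of the set.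

Compound 4 `CC(=O)Nc1cccc(Cn2cc(-c3ccc4cn[nH]c4c3)ccc2=O)c1` differs from compound 3 in one place: hydrogen in place of amino on an aromatic carbon

Going by the values given here, one measured step bears on this change directly, the same replacement made on the shared core: a 2.3-fold higher number from compound 1 to compound 2 (0.37 log units; beyond the scatter). A step of that size and direction is therefore expected here, giving a 2.3-fold higher number from compound 3 to compound 4 (0.35 log units; beyond the scatter). On that basis compound 4 is estimated at 18 nM in this assay, with a range from 9 nM to 40 nM.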

Compound 4, half-maximal inhibitory concentration: 43 nM
The estimate for compound 4 lay 2.4-fold (0.38 log units) below the measured number, outside the stated range (above it).
By their numbers in this assay, from the lowest: compound 3; then compounds 1, 4 and 2 (each within the scatter of the next, the first and the last beyond it).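

Removing the amino group from the acetamido-bearing compound gave a larger step than on the simpler core, a 5.4-fold higher number from compound 3 to compound 4 (0.73 log units; beyond the scatter), so the amino group remains worth keeping on both cores, though the two steps do not differ beyond scatter: the same change on two cores in this assay, a 2.3-fold higher number (0.37 log units; beyond the scatter) from compound 1 to compound 2 and a 5.4-fold higher number (0.73 log units; beyond the scatter) from compound 3 to compound 4, 2.3-fold (0.36 log units) apart, within the scatter of two such steps. Without the amino group, the acetamido step, a 1.7-fold lower number from compound 2 to compound 4 (0.24 log units; within the scatter), lies within the scatter, but its gap from the earlier acetamido step does too: the same change on two cores in this assay, a 4.0-fold lower number (0.60 log units; beyond the scatter) from compound 1 to compound 3 and a 1.7-fold lower number (0.24 log units; within the scatter) from compound 2 to compound 4, 2.3-fold (0.36 log units) apart, within the scatter of two such steps.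

The compounds shown leave open whether a methylamino group, a hydroxyl group or a methyl group on this aromatic carbon would match the amino group.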